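Methyl on the ring amine nitrogen: a second instance

The source may report more compounds than this note shows. Statements on the series, on what has been measured and on what is new or still open speak of the compounds shown alone.

Measured so far in a functional assay on C-33-A cells (Homo sapiens) for antiproliferative activity, read by MTT assay; a lower number here means a stronger inhibitor, a higher number a weaker inhibitor:

compound 1, `c1ccc2c(c1)ccn2-c1nc(N2CCNCC2)nc2ccccc12`: 8.2 ug/mL
compound 2, `CN1CCN(c2nc(-n3ccc4ccccc43)c3ccccc3n2)CC1`: 11.5 ug/mL
compound 3, `Cn1cc(-c2nc(N3CCNCC3)nc3ccccc23)c2ccccc21`: 50 ug/mL

Compound 3 gives the highest number of the three and is the weakest inhibitor in this assay; its gap to compound 2 and its gap to compound 1 both lie beyond the scatter. The difference between the core of compound 3 and the core of compound 1 is not broken down here. Compounds 1 and 2 lie within the scatter of each other.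

One change has already been measured once. From compound 1 to compound 2 the change is methyl in place of hydrogen on an amine nitrogen in a ring, and the step is a 1.4-fold higher number from compound 1 to compound 2 (0.15 log units; within the scatter), within the scatter. The unmeasured compound 4, `CN1CCN(c2nc(-c3cn(C)c4ccccc34)c3ccccc3n2)CC1`, repeats the same change on the core of compound 3: methyl in place of hydrogen on an amine nitrogen in a ring. The place of the change reads the same in both cases, so the two changes are the same change, made twice among the compounds shown.

For compound 4 in this assay the expected step is a 1.2-fold higher number from compound 3 to compound 4 (0.08 log units; within the scatter), small, set beside the earlier one. Because a 1.4-fold higher number from compound 1 to compound 2 (0.15 log units; within the scatter) is within the scatter, the estimate for compound 4 is 60 ug/mL. The expected range for compound 4 runs from 25 ug/mL to 130 ug/mL, with the caution that a single instance is a thin basis and that a number this high may come back only as a limit.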

Compound 4, half-maximal inhibitory concentration: 50 ug/mL
Beside the measured number, compound 4's estimate is 1.2-fold (0.08 log units) above it; the measured number falls inside the stated range.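

Going from piperazin-1-yl to 4-methylpiperazin-1-yl on the core of compound 3 gives, in this assay, no change at the digits printed from compound 3 to compound 4 (within the scatter). Set beside the earlier step, the change carries from one core to the other with no difference that can be told apart: the same change on two cores in this assay, a 1.4-fold higher number (0.15 log units; within the scatter) from compound 1 to compound 2 and no change at the digits printed (within the scatter) from compound 3 to compound 4, 1.4-fold (0.15 log units) apart, within the scatter of two such steps

On these two pairs, methyl in place of hydrogen on the ring amine nitrogen leaves the number within the scatter on both cores, but two pairs do not make a rule for the series, and they do not show that the same would hold on any other core or in any other assay.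

The compounds shown leave open what a group larger than methyl does at this nitrogen, such as an ethyl group, a longer chain ending in a hydroxyl group or an amine, or an acetyl group that turns the nitrogen into an amide. Also open, going by these compounds, is whether a carboxylic acid at the end of such a chain would stay within the scatter on both cores or would separate them.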